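Removing the Phenyl Group from a Sulfonamide Piperidine

A few compounds are considered here, and "the series" means these few. Any claim that something is new, unique, unknown or untested is made for them only; others in the source may bear on it.

Compound 1, `Cc1cc(C)c(S(=O)(=O)N2CCC(N3CCC(c4ccccc4)CC3)CC2)c(C)c1`, is examined in an ADME assay on HCT-116 cells (Homo sapiens) for cytotoxicity, read by CellTiter-Glo, with a stated time of 72 h; a higher number here means a weaker inhibitor, a lower number a stronger inhibitor. In this assay compound 1 gives only a limit, > 5000 nM. Compound 2, `COc1ccc(-c2cccc(S(=O)(=O)N3CCC(N4CCC(C)CC4)CC3)c2)cc1`, likewise returns a limit in this assay, > 5000 nM. Both values sit at the same boundary, (the limit of > 5000 nM in this assay, at which 2 of the 2 values shown sit), so the two compounds cannot be distinguished from each other on these numbers. Compound 3, `Cc1cc(C)c(S(=O)(=O)N2CCC(N3CCCCC3)CC2)c(C)c1`, has not yet been measured. It differs from compound 1 in one place: hydrogen in place of phenyl on a saturated ring carbon. For the measured compounds named here, no measured pair of compounds shows what such a change does in this assay, so the size of the step is uncertain. With both measured values at the limit, a step from compound 1 to compound 3 that stays within the usual scatter seems the most plausible outcome. Compound 3 is expected to give about 8000 nM in this assay, with a range from 3000 nM to 30000 nM. This amounts to an estimated step that the limit leaves unreadable from compound 1 to compound 3.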

Compound 3, half-maximal inhibitory concentration: > 5000 nM
Compound 3 gave a limit, no number; the forecaster's own chance of this, stated with the estimate: 80%; the middle value lies beyond the limit too.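

Compound 3 also returns a limit, > 5000 nM, so no step can be read between compound 1 and compound 3: the limit of > 5000 nM in this assay, at which 3 of the 3 values shown sit.

How much removing the phenyl group changes activity in this assay, and whether any of these compounds would inhibit at higher concentrations, remains open.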